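Dropping one aromatic methyl: what compound 3 should show

A few compounds are considered here, and "the series" means these few. Any claim that something is new, unique, unknown or untested is made for them only; others in the source may bear on it.

Two compounds of this series have numbers in an ADME assay on MT4 cells (Homo sapiens) for cytotoxicity, read by MTT assay, with a stated time of 4 days (on this read-out lower numbers stand for higher toxicity in this test and higher numbers for lower toxicity in this test), so far. Compound 1 `Cc1ccc(-c2c(C)c(-c3ccc4c(c3C)CCCO4)c(C(OC(C)(C)C)C(=O)O)c(C)c2NS(C)(=O)=O)cc1C` gives 24000 nM and holds the higher of the two numbers, which places it on the less toxic side of this small set. Compound 2 `CNc1c(C)c(C(OC(C)(C)C)C(=O)O)c(-c2ccc(C)c(C)c2)c(C)c1-c1ccc(C)c(C)c1` gives 8800 nM and lies lower, by a gap beyond the usual scatter. These two compounds differ in more than one place, so their gap cannot be tied to any single group.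

Compound 3 `Cc1ccc(-c2c(C)c(-c3ccc4c(c3)CCCO4)c(C(OC(C)(C)C)C(=O)O)c(C)c2NS(C)(=O)=O)cc1C` has one change from compound 1: hydrogen in place of methyl on an aromatic carbon on the ring system. Among the measured compounds shown here, no measured pair shows what this kind of change does in this assay here. The expectation therefore starts from compound 1 at 24000 nM as the closest measured structure, and no step beyond the scatter is expected in either direction. The estimated change, a 1.1-fold lower number from compound 1 to compound 3 (0.04 log units; within the scatter) in size, is expected to stay small. For compound 3 the estimated value is 22000 nM with an expected range from 11000 nM to 45000 nM for a single measurement.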

Compound 3, half-maximal cytotoxic concentration: 28000 nM
For compound 3 the middle estimate is 1.3-fold (0.10 log units) below the measured one, and the stated range covers the measured number.
By their numbers in this assay, from the lowest: compound 2; then compounds 1 and 3 (each within the scatter of the next).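

Among the compounds shown here, the pair of compound 1 and compound 3 is the first single-change comparison, and in this assay it gives a 1.2-fold higher number from compound 1 to compound 3 (0.07 log units; within the scatter) for hydrogen in place of methyl on an aromatic carbon. This step lies within the scatter, so at this one position, on the core of compound 1, the read-out does not separate the methyl compound from the hydrogen compound, and this single pair gives no sign that this methyl matters for the number in this test. Nothing measured here explains why the two numbers stay so close, and no supporting evidence bears on this result.

What the compounds shown leave open is whether a larger or different group on this same aromatic carbon, such as a methoxy group, a chlorine atom or an ethyl group, would produce a step beyond the scatter, and whether hydrogen in place of methyl would behave the same way on the core of compound 2 or at another aromatic carbon. The gap between compound 1 and compound 2 also remains untied to any single group, since those two compounds still differ in more than one place.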